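The source may hold more compounds than are shown below. What is called first, only, known or untested is meant among the compounds shown, and "the series" means these compounds.

Compound 3 `CCCC[C@@H](/C=C\[C@@H]1OC(=O)C=C[C@@H]1OC(C)=O)OC(C)=O` is the member of this small set with an acetyl on each free oxygen of the shared core. In a functional assay on KB cells (Homo sapiens) for cytotoxicity, read by sulforhodamine B assay, with a stated time of 72 h (on this read-out lower numbers stand for an effect already at smaller amounts and higher numbers for an effect only at larger amounts of compound), compound 3 gives 1.8 ug/mL. Compound 1 `CCCC[C@@H](/C=C\[C@@H]1OC(=O)C=C[C@@H]1O)OC(C)=O` gives 1.7 ug/mL in this assay, and the step of a 1.1-fold higher number from compound 1 to compound 3 (0.02 log units; within the scatter) shows that putting an acetyl in place of hydrogen on an oxygen on a saturated carbon leaves the number within the scatter, so no order can be read between these two. The remaining value is a limit rather than a number: compound 2 `CCCC[C@@H](/C=C\[C@@H]1OC(=O)C[C@@H](OC)[C@@H]1O)OC(C)=O`, built on a different core, reaches only > 20 ug/mL in this assay, which is the limit of > 20 ug/mL in this assay, at which 1 of the 3 values shown sits.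

Compound 4 `CCCC[C@H](O)/C=C\[C@@H]1OC(=O)C=C[C@@H]1OC(C)=O` differs from compound 3 by hydrogen in place of acetyl on an oxygen on a saturated carbon. Among the compounds with values here, the only measured step that bears on this is the one from compound 1 to compound 3, an exchange of acetyl and hydrogen at an oxygen on a saturated carbon, and it stayed within the scatter. The step of a 1.1-fold higher number from compound 3 to compound 4 (0.05 log units; within the scatter) is therefore expected to stay within the scatter as well. Compound 4 is estimated at 2 ug/mL in this assay, with a range from 0.8 ug/mL to 5 ug/mL.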

Compound 4, concentration for half-maximal effect: 1.4 ug/mL
Estimate against measurement, compound 4: 1.4-fold (0.15 log units) above; the measured number falls inside the stated range.
By their numbers in this assay, from the lowest: compounds 4, 1 and 3 (each within the scatter of the next). At a limit, above all of these: compound 2.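

In this assay the step of a 1.3-fold lower number from compound 3 to compound 4 (0.11 log units; within the scatter) shows that the acetyl on the oxygen on a saturated carbon whose other neighbours are: saturated chain carbon can give way to hydrogen with the number staying within the scatter. The earlier step, a 1.1-fold higher number from compound 1 to compound 3 (0.02 log units; within the scatter), covered only the other oxygen, so each of the two acetyl groups of compound 3 has now been exchanged for hydrogen once, and neither exchange moved the number beyond the scatter. Nothing among the data shown explains why this exchange leaves the number within the scatter.

On these data alone, whether a benzoyl on this oxygen, or an amine in place of it, would keep the number in this range remains open. Also open, as far as these compounds go, is what hydrogen on both oxygens at once would give.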